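The source may hold more compounds than are shown below. What is called first, only, known or untested is meant among the compounds shown, and "the series" means these compounds.

Measured in a functional assay on HepG2 cells (Homo sapiens) for inhibition, read by MTT assay, with a stated time of 3 days (a lower number here means a stronger inhibitor, a higher number a weaker inhibitor), so far
compound 1 `COc1cc(-c2nc3ccccc3s2)ccc1OCC(=O)NNC(=O)CN[C@@H](CS)C(=O)O` gives 3120 nM in this series
compound 2 `COc1cc(-c2nc3ccccc3s2)ccc1OCC(=O)NNC(=O)CN(C(C)=O)[C@@H](CS)C(=O)O` gives 3420 nM in this series
compound 3 `CCOC(=O)CN(C)CC(=O)NNC(=O)COc1ccc(-c2nc3ccccc3s2)cc1OC` gives 3180 nM in this series

All three values lie within the scatter of one another, and compound 1 holds no rank of its own among them. Compound 4 `CCOC(=O)[C@@H](NCC(=O)NNC(=O)COc1ccc(-c2nc3ccccc3s2)cc1OC)[C@@H](C)CC` is not yet measured. The change from compound 1 reads 1-(ethoxycarbonyl)-2-methylbutyl in place of 1-carboxy-2-sulfanylethyl on an amine nitrogen and amounts to 1-(ethoxycarbonyl)-2-methylbutyl in place of 1-carboxy-2-sulfanylethyl on an amine nitrogen.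

The closest measured change is a 1.0-fold higher number from compound 1 to compound 3 (0.01 log units; within the scatter) where the same amino group gives way to ((ethoxycarbonyl)methyl)(methyl)amino. The other two steps are a 1.1-fold higher number from compound 1 to compound 2 (0.04 log units; within the scatter) and a 1.1-fold lower number from compound 2 to compound 3 (0.03 log units; within the scatter) and neither leaves the scatter. Within the data shown here, no measured compound carries the 1-(ethoxycarbonyl)-2-methylbutyl group, and that limits the inference. In this assay the expected step is a 1.0-fold lower number from compound 1 to compound 4 (0.00 log units; within the scatter) and nothing beyond the scatter is anticipated. Compound 4 is estimated at 3100 nM with an expected range of 1600 nM to 6000 nM for now.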

Compound 4, half-maximal inhibitory concentration: 3460 nM
Compound 4: middle estimate off by 1.1-fold (0.05 log units), on the low side; the range from low to high includes it.
By their numbers in this assay, from the lowest: compounds 1, 3, 2 and 4 (each within the scatter of the next).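

In this assay, a 1.1-fold higher number from compound 1 to compound 4 (0.04 log units; within the scatter) shows that this amine nitrogen tolerates a branched carbon side chain carrying an ethyl ester, with no carboxy or sulfanyl group, without leaving the scatter. The same holds against the tertiary amine and the acetylated amine, with a 1.1-fold higher number from compound 3 to compound 4 (0.04 log units; within the scatter) and a 1.0-fold higher number from compound 2 to compound 4 (0.01 log units; within the scatter), so neither the larger 1-(ethoxycarbonyl)-2-methylbutyl group nor its second defined stereocentre separates compound 4 from the others. No data offer an explanation for this flat response.

On these data alone, whether a benzyl group or a free carboxylic acid in place of the ethyl ester on the same branched chain would move the number beyond the scatter remains open. Also open, as far as these compounds go, is whether any change on this side of the shared core affects the read-out.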